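The source may hold more compounds than are shown below. What is called first, only, known or untested is meant among the compounds shown, and "the series" means these compounds.

Measured in a functional assay on MCF7 cells (Homo sapiens) for antiproliferative activity, read by sulforhodamine B assay, with a stated time of 48 h; on this read-out lower numbers stand for stronger inhibition and higher numbers for weaker inhibition:
- Compound 1 `CCc1ccccc1NS(=O)(=O)c1ccc(N2CCNC2=O)cc1`: 350 nM
- Compound 2 `CC(C)(C)c1ccc(NS(=O)(=O)c2ccc(N3CCNC3=O)cc2)cc1`: > 1000 nM

Compound 2 has no exact number, only a limit of > 1000 nM. Compound 3 `CCCCCCOc1ccc(NS(=O)(=O)c2ccc(N3CCNC3=O)cc2)cc1` has hexyloxy in place of tert-butyl on an aromatic carbon, para to a large group (hexyloxy in place of tert-butyl on an aromatic carbon). Within the data shown here, no measured step yet shows what such a change does in this assay. Only a small step toward weaker inhibition, or none beyond the scatter, is expected, with an estimated step that the limit leaves unreadable from compound 2 to compound 3. The estimated value for compound 3 is 1500 nM, with an expected range of 400 nM to 6000 nM.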

Compound 3, half-maximal inhibitory concentration: > 1000 nM
Compound 3 gave a limit, no number; the forecaster's own chance of this, stated with the estimate: 50%; the middle value lies beyond the limit too.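

Compound 2 and compound 3 both give only a limit and no number, so no step can be read between them: the limit of > 1000 nM in this assay, at which 2 of the 3 values shown sit. As far as these compounds go, whether hexyloxy in place of tert-butyl strengthens or weakens inhibition stays open.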